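The compounds below may be only part of what the source reports. "The series", "measured", "known", "first", "only" and "open" are said of these compounds alone.

Measured compounds in the series:
- compound 1 `COc1cc2ncnc(NNC(=S)NC(=O)c3ccccc3Cl)c2cc1OC` — 9670 nM
- compound 2 `COc1cc2ncnc(NNC(=S)NC(=O)c3ccccc3F)c2cc1OC` — 12700 nM

In a functional assay on CNE-2 cells (Homo sapiens) for cytotoxicity, read by MTT assay, with a stated time of 72 h (a lower number here means a stronger inhibitor, a higher number a weaker inhibitor), compound 2 gives the highest of the two numbers; its nearest neighbour is compound 1, and the step of a 1.3-fold higher number from compound 1 to compound 2 (0.12 log units; within the scatter) is small. Compound 3 `COc1cc2ncnc(NNC(=S)NC(=O)c3ccccc3OC)c2cc1OC` is not yet measured. It differs from compound 2 by methoxy in place of fluoro on an aromatic carbon, the same difference cut one bond further out reading 2-fluorophenyl to 2-methoxyphenyl. Going by the values given here, the only measured step that touches this position is the exchange of chloro for fluoro on the same aromatic carbon, a 1.3-fold higher number from compound 1 to compound 2 (0.12 log units; within the scatter), which stayed within the scatter. Among the compounds with values here, no measured step covers methoxy at this carbon, so the expectation rests on that single small step alone. The step of a 1.2-fold lower number from compound 2 to compound 3 (0.06 log units; within the scatter) is therefore expected to be of no more than the usual scatter, in no firm direction. Compound 3 is estimated at 11000 nM, with a range from 4000 nM to 30000 nM.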

Compound 3, half-maximal inhibitory concentration: 8410 nM
Estimate against measurement, compound 3: 1.3-fold (0.12 log units) above, within the range that was stated.
By their numbers in this assay, from the lowest: compounds 3, 1 and 2 (each within the scatter of the next).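

Methoxy now joins chloro and fluoro on this aromatic carbon, ortho to a large group, and in this assay neither exchange leaves the scatter: a 1.5-fold lower number from compound 2 to compound 3 (0.18 log units; within the scatter) and a 1.1-fold lower number from compound 1 to compound 3 (0.06 log units; within the scatter). The earlier compounds shown here compared only two halogens, whereas this change also brings in a hydrogen-bond acceptor and a group with more heavy atoms, and the three compounds still cannot be separated by their numbers. No available data bear on the reason for this result.

From the compounds shown here alone, it remains open whether an amine, a carboxylic acid or a longer chain such as butoxy on this carbon would give a step beyond the scatter. Also open, going by these compounds, is whether chloro, fluoro and methoxy would stay this close on another carbon of the same ring.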